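Aryl amine variation in a benzamide series: note on compound 4

The source may report more compounds than this note shows. Statements on the series, on what has been measured and on what is new or still open speak of the compounds shown alone.

Measured compounds, with their values in an assay on HeLa cells for binding affinity to Vasopressin V2 receptor (Homo sapiens); on this read-out higher numbers stand for weaker inhibition and lower numbers for stronger inhibition:
compound 1 `CCN(CC)c1ccc(C(=O)N2CCCCc3ccccc32)c(Cl)c1`: 19 nM
compound 2 `CCCNc1ccc(C(=O)N2CCCCc3ccccc32)c(Cl)c1`: 18 nM
compound 3 `C=CCNc1ccc(C(=O)N2CCCCc3ccccc32)c(Cl)c1`: 5.9 nM

Compound 3 gives the lowest number of the three. The step of a 3.1-fold lower number from compound 2 to compound 3 (0.48 log units; beyond the scatter) and the step of a 3.2-fold lower number from compound 1 to compound 3 (0.51 log units; beyond the scatter) both lie beyond the scatter, whereas the step of a 1.1-fold lower number from compound 1 to compound 2 (0.02 log units; within the scatter) lies within it, so compound 1 and compound 2 cannot be ordered against each other.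

Compound 4 `O=C(c1ccc(N2CCCC2)cc1Cl)N1CCCCc2ccccc21` is not yet measured. It differs from compound 3 in that (pyrrolidin-1-yl in place of allylamino on an aromatic carbon). For the measured compounds named here, the change removes the allylamino group, the one feature that set compound 3 apart from compound 1 and compound 2, and brings in a ring-closed amine without a hydrogen-bond donor, structurally nearer to the diethylamino of compound 1 than to the allylamino of compound 3. Going by the values given here, the steps that bear on it are a 3.2-fold lower number from compound 1 to compound 3 (0.51 log units; beyond the scatter) and a 3.1-fold lower number from compound 2 to compound 3 (0.48 log units; beyond the scatter), read in reverse; both were modest. A modest rise in the number in this assay is therefore expected for compound 4, back toward the level of compound 1, the expected step being a 2.5-fold higher number from compound 3 to compound 4 (0.41 log units; beyond the scatter). The estimate for compound 4 in this assay is 15 nM, with a range from 5 nM to 45 nM.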

Compound 4, half-maximal inhibitory concentration: 9 nM
For compound 4 the middle estimate is 1.7-fold (0.22 log units) above the measured one; the range from low to high includes it.
By their numbers in this assay, from the lowest: compounds 3, 4, 2 and 1 (each within the scatter of the next, the first and the last beyond it).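

In this assay, the step of a 1.5-fold higher number from compound 3 to compound 4 (0.18 log units; within the scatter) shows that this position on the aromatic ring does not depend on allylamino: pyrrolidin-1-yl, with one five-membered non-aromatic ring, 0 hydrogen-bond donors and no double bond outside aromatic rings, cannot be separated from it. The step of a 2.0-fold lower number from compound 2 to compound 4 (0.30 log units; within the scatter) leaves compound 4 equally unordered against the propylamino analogue, so the clear gap that set allylamino apart from propylamino does not mark out a unique group at this position. The step of a 2.1-fold lower number from compound 1 to compound 4 (0.32 log units; beyond the scatter) is the only one of the three beyond the scatter and is modest, which indicates that closing the amine into a ring is not equivalent to the open diethylamino group, even though the two ring-bearing and open amines were treated as neighbours before this result.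

Open, going by these compounds, is whether a piperidin-1-yl or morpholin-4-yl ring, or a tertiary amine carrying both an allyl and a methyl group, would stay level with compound 3 and compound 4 or return toward compound 1. No measurement shown here accounts for any of these differences.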